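The source may report more compounds than this note shows. Statements on the series, on what has been measured and on what is new or still open speak of the compounds shown alone.

Working notes on the series.

Three compounds of the series have been run through an ADME assay on liver for metabolic stability, with Liver microsome (Homo sapiens) as the target, read by LC-MS, using microsomes; on this read-out lower numbers stand for slow clearance and higher numbers for fast clearance. Compound 1 `CC(C)(C)OC[C@@H](O)C(=O)N1[C@H](C(=O)NCc2cc(Cl)ccc2-n2cnnn2)C[C@@H]2C[C@@H]21` gives 21 mL.min-1.g-1 in this assay. Compound 2 `O=C(NCc1cc(Cl)ccc1-n1cnnn1)[C@@H]1C[C@@H]2C[C@@H]2N1C(=O)[C@H](O)C1CCCCC1` gives 150 mL.min-1.g-1, and compound 3 `O=C(NCc1cc(Cl)ccc1-n1cnnn1)[C@@H]1[C@H]2C[C@H]2CN1C(=O)[C@H](O)C1CCCCC1` gives 110 mL.min-1.g-1; the two values of compound 2 and compound 3 lie within the scatter of each other. Compound 2 and compound 3 carry the same atoms joined differently, and the difference between the two cores is not broken down here.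

For the measured compounds named here, the one counted step among the measured compounds is (tert-butoxy)methyl in place of cyclohexyl on a saturated chain carbon bound to a carbonyl carbon and an oxygen on a saturated carbon, which produced a 7.1-fold lower number from compound 2 to compound 1 (0.85 log units; beyond the scatter) in this assay. Compound 4 `CC(C)(C)OC[C@@H](O)C(=O)N1C[C@@H]2C[C@@H]2[C@H]1C(=O)NCc1cc(Cl)ccc1-n1cnnn1` remains unmeasured; it differs from compound 3 by (tert-butoxy)methyl in place of cyclohexyl on a saturated chain carbon bound to a carbonyl carbon and an oxygen on a saturated carbon, the same change that was made from compound 2 to compound 1, in the same place.

For compound 4 the expectation rests on compound 3 at 110 mL.min-1.g-1 and on the earlier step of a 7.1-fold lower number from compound 2 to compound 1 (0.85 log units; beyond the scatter) in this assay, so compound 4 is expected to show a 6.1-fold lower number from compound 3 to compound 4 (0.79 log units; beyond the scatter). Compound 4 is therefore estimated at 18 mL.min-1.g-1 in this assay, between 8 mL.min-1.g-1 and 40 mL.min-1.g-1.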

Compound 4, intrinsic clearance in microsomes: 37 mL.min-1.g-1
Beside the measured number, compound 4's estimate is 2.1-fold (0.31 log units) below it; the range from low to high includes it.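

In this assay, (tert-butoxy)methyl in place of cyclohexyl gives a 3.0-fold lower number from compound 3 to compound 4 (0.47 log units; beyond the scatter), the same direction as on the other core. Set beside the earlier step, the size of the change does not differ beyond the scatter: the same change on two cores in this assay, a 7.1-fold lower number (0.85 log units; beyond the scatter) from compound 2 to compound 1 and a 3.0-fold lower number (0.47 log units; beyond the scatter) from compound 3 to compound 4, 2.4-fold (0.38 log units) apart, within the scatter of two such steps. The change therefore carries from one core to the other in these two matched pairs, but this does not show that it would transfer to any further core, and the pairs give no reason for the lower numbers.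

The compounds shown leave open whether the drop follows from the loss of the cyclohexyl ring, the ether oxygen or the tert-butyl group, since all three differ at once in this single replacement. A methoxymethyl chain or a tetrahydropyran-4-yl ring at the same place on a saturated chain carbon bound to a carbonyl carbon and an oxygen on a saturated carbon would help to separate these parts.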